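A few compounds are considered here, and "the series" means these few. Any claim that something is new, unique, unknown or untested is made for them only; others in the source may bear on it.

Compound 2, `CCCCCCc1ccc(-c2c(C)[nH]c(=O)n2C)cc1`, gives 0.3 mg/kg in a functional assay on the whole organism with Rattus norvegicus as the target; a lower number here means that less compound is needed, a higher number that more compound is needed for the effect. Compound 3, `CCCCCCCCCCc1ccc(-c2c(C)[nH]c(=O)n2C)cc1`, gives 0.3 mg/kg. Compound 1, `Cc1[nH]c(=O)n(C)c1-c1ccc(CC(C)C)cc1`, gives 30 mg/kg.

Compound 2 stands level with compound 3 at the digits shown, the two together giving the lowest numbers of the three, while compound 1 lies far away: the step is a 100-fold lower number from compound 1 to compound 2 (2.00 log units; beyond the scatter). Compound 4, `Cc1[nH]c(=O)n(C)c1-c1ccc(-c2ccccc2)cc1`, has not yet been measured. It differs from compound 2 in one place: phenyl in place of hexyl on an aromatic carbon.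

Among the compounds with values here, two measured steps concern the same position on the ring. Pentyl in place of isopropyl gave a 100-fold lower number from compound 1 to compound 2 (2.00 log units; beyond the scatter), a large change, whereas butyl in place of hydrogen further along the chain gave no change at the digits printed from compound 2 to compound 3 (within the scatter). Neither step exchanges a chain for a ring, so they bear on the change to compound 4 only loosely: the position accepts hexyl and decyl equally well, but isobutyl gives a much higher number, and nothing measured speaks to phenyl. Because a 100-fold lower number from compound 1 to compound 2 (2.00 log units; beyond the scatter) shows the position to be sensitive to what sits there, the estimate is uncertain. For compound 4 a modest rise in the number, a 3.3-fold higher number from compound 2 to compound 4 (0.52 log units; beyond the scatter), is expected. For compound 4 the estimate in this assay is 1 mg/kg, with a range from 0.3 mg/kg to 10 mg/kg.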

Compound 4, minimum effective dose: 0.3 mg/kg
For compound 4 the middle estimate is 3.3-fold (0.52 log units) above the measured one; the range from low to high includes it.
By their numbers in this assay, from the lowest: compounds 2, 3 and 4 (each within the scatter of the next); then compound 1.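

In this assay, the group on this aromatic carbon need not be a saturated chain: with phenyl in place of hexyl, the result is no change at the digits printed from compound 2 to compound 4 (within the scatter). Hexyl and phenyl share their count of 6 heavy atoms, all carbon, but only phenyl has a ring, so this position accepts a six-membered aromatic ring of carbon only as well as an open chain. The second step, a 100-fold lower number from compound 1 to compound 4 (2.00 log units; beyond the scatter), sets phenyl apart from isobutyl, and among the compounds shown isobutyl now stands alone against hexyl, decyl and phenyl, though nothing available explains why the position accepts these three groups and gives so much higher a number with isobutyl.

Still open, from the compounds shown here alone, is whether a shorter straight chain such as propyl would behave like hexyl or like isobutyl. Also open, going by these compounds, is whether a group containing nitrogen or oxygen, such as an amine, a carboxylic acid or a phenyl ring carrying a methoxy group, would be accepted at this position as well as phenyl itself.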